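Bromo to tert-butyl in a narrow solubility series

A few compounds are considered here, and "the series" means these few. Any claim that something is new, unique, unknown or untested is made for them only; others in the source may bear on it.

In a physicochemical assay for solubility, using potentiometric titration (on this read-out higher numbers stand for higher solubility and lower numbers for lower solubility), compound 2 (`Fc1ccc(-c2nc(-c3ccc(Br)cc3)no2)cc1F`) gives 77000 nM as its reading and sits within the scatter of both other measured compounds. Those are compound 3 (`COc1cccc(-c2noc(-c3ccc(F)c(F)c3)n2)c1`), which gives 86000 nM on the same read-out, and compound 1 (`Fc1ccc(-c2nc(-c3ccc4nc[nH]c4c3)no2)cc1F`), which gives 99000 nM on the same read-out. All three values thus lie within the scatter of one another, although the compounds differ in their substituents.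

Compound 4 (`CC(C)(C)c1ccc(-c2noc(-c3ccc(F)c(F)c3)n2)cc1`), not yet measured, differs from compound 2 in one place (tert-butyl in place of bromo on an aromatic carbon), with tert-butyl in place of bromo on an aromatic carbon. Among the measured compounds shown here, no measured pair shows this change, so the expectation rests only on the narrow spread of the three values. A small drop in this assay is expected, with no step beyond the scatter, and it is estimated as a 1.2-fold lower number from compound 2 to compound 4 (0.07 log units; within the scatter) on this read-out. For compound 4 the estimated value is 65000 nM within an expected range of 30000 nM to 100000 nM on this read-out.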

Compound 4, solubility: 91000 nM
Estimate against measurement, compound 4: 1.4-fold (0.15 log units) below; the measured number falls inside the stated range.
By their numbers in this assay, from the lowest: compounds 2, 3, 4 and 1 (each within the scatter of the next).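

In this assay, placing tert-butyl in place of bromo on an aromatic carbon, para to a large group, gives a 1.2-fold higher number from compound 2 to compound 4 (0.07 log units; within the scatter), the only step shown here in which a single place changes. It shows that, at this position and in this pair, a group of 4 heavy atoms (4 carbon) can take the place of one of 1 heavy atom (1 bromine) with the reading staying inside the scatter. The compounds shown offer no measured basis for explaining this result.

Going by these compounds, what remains open is whether an amine or a carboxylic acid at this same place would also leave the reading inside the scatter. A single pair also cannot say whether this step would hold on the other cores shown, such as that of compound 1.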